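The source may report more compounds than this note shows. Statements on the series, on what has been measured and on what is new or still open speak of the compounds shown alone.

Working notes on the series, read in a functional assay on Huh-5-2 cells (Homo sapiens) for cytotoxicity, read by microscopy; a higher number here means that more compound is tolerated, a lower number that less compound is tolerated. Compound 1 `CC(=O)OC[C@H]1O[C@@H](n2c(SCc3cc4ccccc4oc3=O)nc3cncnc32)[C@H](OC(C)=O)[C@@H]1OC(C)=O` gives 39000 nM. Compound 2 `CC(=O)OC[C@H]1O[C@@H](n2c(SCc3cc4ccccc4oc3=O)nc3cncnc32)[C@H](O)[C@@H]1O` gives 8700 nM, and compound 3 `CC(=O)OC[C@H]1O[C@@H](n2c(SCc3cc4cc(F)ccc4oc3=O)nc3cncnc32)[C@H](O)[C@@H]1O` gives 8600 nM. Compound 3 has the lowest number of the three, but it is level with compound 2 within the scatter, and both values lie well under that of compound 1.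

The next change leads to compound 4 `CC(=O)OC[C@H]1O[C@@H](n2c(SCc3cc4cc(C)ccc4oc3=O)nc3cncnc32)[C@H](O)[C@@H]1O`: methyl in place of fluoro on an aromatic carbon. Within the data shown here, one measured step bears on it, the change from hydrogen to fluoro on an aromatic carbon, which is a 1.0-fold lower number from compound 2 to compound 3 (0.01 log units; within the scatter). That step shows no response to substitution there, but no methyl has been measured in this series, so the guidance is indirect. No step beyond the scatter is therefore expected in this assay, and no direction is favoured.

The step expected for compound 4 is a 1.1-fold lower number from compound 3 to compound 4 (0.03 log units; within the scatter). The estimated value for compound 4 is 8000 nM, with an expected range of 4000 nM to 16000 nM.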

Compound 4, half-maximal cytotoxic concentration: 16000 nM
Estimate against measurement, compound 4: 2.0-fold (0.30 log units) below; the measured number falls inside the stated range.
By their numbers in this assay, from the lowest: compounds 3, 2 and 4 (each within the scatter of the next); then compound 1.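

In this assay, methyl in place of fluoro on this aromatic carbon gives a 1.9-fold higher number from compound 3 to compound 4 (0.27 log units; within the scatter) and methyl in place of hydrogen gives a 1.8-fold higher number from compound 2 to compound 4 (0.26 log units; within the scatter) in the same series. Among these compounds, both steps lie within the scatter, so compounds 2, 3 and 4 stand level and this position, which had so far been probed only with fluoro, now shows no measurable response to methyl either.

The compounds shown leave open whether an amine, a carboxylic acid or a longer chain on this aromatic carbon would give a step beyond the scatter. They also leave open whether methyl or fluoro would stay level with hydrogen on the fully acetylated sugar of compound 1.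

No measurement at hand offers an explanation for these values.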